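This account rests on a few compounds, and the source may have more. Where it says the series, first, only, none or still open, it means among the compounds named here.

In a functional assay on HL-60 cells (Homo sapiens) for cytotoxicity, read by WST assay, with a stated time of 48 h (a lower number here means that less compound is needed, a higher number that more compound is needed for the effect), compound 1 `COc1ccc(C[C@H]2COC(=O)[C@@H]2Cc2ccc(Cl)c(Cl)c2)cc1` gives 37000 nM and compound 2 `CCc1ccc(C[C@H]2COC(=O)[C@@H]2Cc2ccc(Cl)c(Cl)c2)cc1` gives 16000 nM. Going by the values given here, compound 2 therefore holds the lower of the only two numbers measured so far, although both values are high and a large amount of compound is needed for the effect.

The next structure is compound 3 `O=C1OC[C@H](Cc2ccc(Cl)c(Cl)c2)[C@H]1Cc1ccc(Cl)c(Cl)c1`. Here 3,4-dichlorophenyl takes the place of 4-ethylphenyl on a saturated chain carbon bound to a saturated ring carbon: 3,4-dichlorophenyl in place of 4-ethylphenyl on a saturated chain carbon bound to a saturated ring carbon. Compound 3 thus carries the 3,4-dichlorophenyl group already present in compound 1 and compound 2 a second time.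

Among the compounds with values here, only one measured step offers guidance. Putting ethyl in place of methoxy on an aromatic carbon gave a 2.3-fold lower number from compound 1 to compound 2 (0.36 log units; beyond the scatter), a modest change beyond the scatter. That step altered a smaller part of the same aromatic group, so it is a loose guide, and it gives no direct evidence on a dichlorophenyl group at this place. A modest further move in this assay is the cautious expectation, with an estimated 2.1-fold lower number from compound 2 to compound 3 (0.33 log units; beyond the scatter).

For compound 3, the expected value is 7500 nM, with an estimated range of 2500 nM to 25000 nM.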

Compound 3, half-maximal effective concentration: 20000 nM
Compound 3: the middle estimate sits 2.7-fold (0.43 log units) below what was measured, within the range that was stated.
By their numbers in this assay, from the lowest: compounds 2, 3 and 1 (each within the scatter of the next, the first and the last beyond it).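

Going by these compounds alone, this exchange replaces the whole aromatic group at this place, on a saturated chain carbon bound to a saturated ring carbon, whereas the earlier step altered only one group on that ring. In this assay, 3,4-dichlorophenyl in place of 4-ethylphenyl gives a 1.3-fold higher number from compound 2 to compound 3 (0.10 log units; within the scatter), so this assay does not separate these two groups here. Against 4-methoxyphenyl, the same group gives a 1.9-fold lower number from compound 1 to compound 3 (0.27 log units; within the scatter), which means compound 3 cannot be separated from either neighbour, even though compound 1 and compound 2 lie beyond the scatter of each other. Nothing measured alongside these numbers offers an explanation for this result.

From the compounds shown here alone, all three compounds carry a substituted phenyl group at this place and keep 3,4-dichlorophenyl at the other, so the effect of an amine, a carboxylic acid or a longer chain at this place remains open. Also open, going by these compounds, is whether a phenyl group with a single chlorine would behave like 3,4-dichlorophenyl, and whether any change to the shared core would bring the numbers in this assay down from their present high level.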